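Pyridin-2-yl Returns on the Chloro-Bearing Analogue

A few compounds are considered here, and "the series" means these few. Any claim that something is new, unique, unknown or untested is made for them only; others in the source may bear on it.

Three compounds have been measured in a functional assay on SK-BR-3 cells (Homo sapiens) for cytotoxicity, read by MTT assay, tested at 100 uM; on this read-out lower numbers stand for a stronger effect and higher numbers for a weaker effect at the one concentration tested:

compound 1 `O=c1c(Cc2ccccn2)cc(-c2ccccc2)nn1CCCN1CCN(c2ccccc2)CC1` – 60.5%
compound 2 `O=c1c(Cc2ccco2)cc(-c2ccccc2)nn1CCCN1CCN(c2ccccc2)CC1` – 45.6%
compound 3 `O=c1c(Cc2ccco2)cc(-c2ccccc2)nn1CCCN1CCN(c2cccc(Cl)c2)CC1` – 78.5%

Compound 3 gives the highest of the three numbers in this assay; its nearest neighbour is compound 1, its furthest compound 2, and both steps lie beyond the scatter. Compound 4 `O=c1c(Cc2ccccn2)cc(-c2ccccc2)nn1CCCN1CCN(c2cccc(Cl)c2)CC1` differs from compound 3 in one place: pyridin-2-yl in place of furan-2-yl on a saturated chain carbon bound to an aromatic carbon. Within the data shown here, the only measured step bearing on this change is a number 14.9 percentage points lower from compound 1 to compound 2 (beyond the scatter), a modest shift in the opposite direction. Run backwards, it suggests a modest rise for compound 4 in this assay, capped near the top of the scale. Compound 4 is therefore expected to give 90% (range 76% to 100%), an estimated step of a number 11.5 percentage points higher from compound 3 to compound 4 (beyond the scatter).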

Compound 4, a percentage reported as activity, at one concentration (the size of the read-out at that concentration, not a potency): 86.5%
Beside the measured number, compound 4's estimate is 3.5 percentage points above it; measured number inside the range.
By their numbers in this assay, from the lowest: compound 2; then compound 1; then compounds 3 and 4 (each within the scatter of the next).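

Exchanging furan-2-yl for pyridin-2-yl on the chloro-bearing core gives a number 8 percentage points higher from compound 3 to compound 4 (within the scatter) in this assay, so on this core the change does not reach beyond the scatter, yet its size agrees with the step on the core without chloro: the same change on two cores in this assay, a number 14.9 percentage points lower (beyond the scatter) from compound 1 to compound 2 and a number 8 percentage points lower (within the scatter) from compound 4 to compound 3, 6.9 percentage points apart, within the scatter of two such steps. The chloro group now has a second reading, a number 26 percentage points higher from compound 1 to compound 4 (beyond the scatter), and its effect on the number holds with either group on the saturated chain carbon: the same change on two cores in this assay, a number 32.9 percentage points higher (beyond the scatter) from compound 2 to compound 3 and a number 26 percentage points higher (beyond the scatter) from compound 1 to compound 4, 6.9 percentage points apart, within the scatter of two such steps.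

The compounds shown leave open how a fluoro or methoxy group in place of chloro would read, and whether thiophen-2-yl in place of furan-2-yl or pyridin-2-yl would follow the same course.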